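The source may report more compounds than this note shows. Statements on the series, on what has been measured and on what is new or still open speak of the compounds shown alone.

Of the compounds shown here, two have so far been tested in a functional assay on B16-F10 cells (Mus musculus) for antiproliferative activity, read by ELISA and MTT assay, with a stated time of 48 h; a lower number here means a stronger inhibitor, a higher number a weaker inhibitor. Compound 1, `O=C(/C=C/c1ccc(Cl)cc1)NS(=O)(=O)c1ccc(F)cc1`, gives 2 ug/mL in this assay. Compound 2, `O=C(/C=C/c1ccc(Cl)cc1)NS(=O)(=O)c1ccc(Cl)cc1`, gives 2.5 ug/mL in this assay. For the measured compounds named here, the one measured step, a 1.3-fold higher number from compound 1 to compound 2 (0.10 log units; within the scatter), covers chloro in place of fluoro on an aromatic carbon and shows no movement beyond the scatter. Of the two numbers shown, the number for compound 2 is not separated from that of compound 1 beyond the scatter. Compound 3, `O=C(/C=C/c1ccc(Cl)cc1)NS(=O)(=O)c1ccc(Br)cc1`, is not yet measured; it differs from compound 2 in this way: bromo in place of chloro on an aromatic carbon. This is a change of the same kind, one halogen for another at the same place on the same ring. Going by the values given here, because the only comparable step, a 1.3-fold higher number from compound 1 to compound 2 (0.10 log units; within the scatter), stayed within the scatter, the expected step of a 1.2-fold higher number from compound 2 to compound 3 (0.08 log units; within the scatter) is also small, with no clear direction. Compound 3 is therefore estimated at 3 ug/mL, with a likely range from 1.5 ug/mL to 6 ug/mL in this assay.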

Compound 3, half-maximal inhibitory concentration: 2.8 ug/mL
Compound 3: middle estimate off by 1.1-fold (0.03 log units), on the high side, within the range that was stated.
By their numbers in this assay, from the lowest: compounds 1, 2 and 3 (each within the scatter of the next).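

In this assay, putting 4-bromophenyl in place of 4-chlorophenyl gives a 1.1-fold higher number from compound 2 to compound 3 (0.05 log units; within the scatter) and thus a second halogen exchange at this place on the ring that leaves the reading within the scatter. Comparing the fluoro and bromo compounds directly gives a 1.4-fold higher number from compound 1 to compound 3 (0.15 log units; within the scatter) and shows that the widest exchange among these three halogens also stays within the scatter, something the single chloro-for-fluoro step could not show. No evidence is available to explain why these three compounds read so alike.

The compounds shown carry only halogens at this place, so it remains open whether an amine, a carboxylic acid or a methoxy group there would give a clearly different number. Also open, going by these compounds, is whether changing the chloro group on the second aromatic ring, which all three compounds share, would matter.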